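The compounds below may be only part of what the source reports. "The series", "measured", "known", "first", "only" and "open" are said of these compounds alone.

In an ADME assay on L02 cells (Homo sapiens) for cytotoxicity, read by MTT assay, with a stated time of 24 h (on this read-out higher numbers stand for weaker inhibition and lower numbers for stronger inhibition), the measured compounds stand as follows:

compound 1 `O=C1/C(=C/c2ccncc2)CN(S(=O)(=O)c2ccc([N+](=O)[O-])cc2)C/C1=C\c1ccccc1F` — 18400 nM
compound 2 `O=C1/C(=C/c2ccncc2)CN(S(=O)(=O)c2ccc(C(F)(F)F)cc2)C/C1=C\c1ccccc1F` — 18600 nM
compound 3 `O=C1/C(=C/c2ccncc2)CN(S(=O)(=O)c2ccc(Cl)cc2)C/C1=C\c1ccccc1F` — 15000 nM

Compound 3 stands apart from its two neighbours only by steps within the scatter: a 1.2-fold lower number from compound 1 to compound 3 (0.09 log units; within the scatter) and a 1.2-fold lower number from compound 2 to compound 3 (0.09 log units; within the scatter). Between the other two, a 1.0-fold higher number from compound 1 to compound 2 (0.00 log units; within the scatter) is likewise within the scatter. All three measured steps are exchanges of the group on the same aromatic carbon of the sulfonyl-bound ring, and none of them moved the number beyond the scatter.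

Compound 4 `CC(=O)Nc1ccc(S(=O)(=O)N2C/C(=C\c3ccncc3)C(=O)/C(=C/c3ccccc3F)C2)cc1` continues the same exchange on that carbon, (acetamido in place of chloro on an aromatic carbon). The acetamido group brings what none of the three measured groups carried, so the measured steps set the expectation only loosely. For the measured compounds named here, every exchange at this position so far has stayed within the scatter, and for compound 4 the expected step is a 1.1-fold higher number from compound 3 to compound 4 (0.05 log units; within the scatter). The number for compound 4 in this assay is therefore estimated at 17000 nM, within a range from 8000 nM to 40000 nM.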

Compound 4, half-maximal inhibitory concentration: 12300 nM
Compound 4: the middle estimate sits 1.4-fold (0.14 log units) above what was measured; the range from low to high includes it.
By their numbers in this assay, from the lowest: compounds 4, 3, 1 and 2 (each within the scatter of the next).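

In this assay, acetamido brings 4 heavy atoms, with 1 hydrogen-bond donor and 1 hydrogen-bond acceptor, in place of the single chlorine, and the result is (a 1.2-fold lower number from compound 3 to compound 4 (0.09 log units; within the scatter)). Against the other two groups, the steps are (a 1.5-fold lower number from compound 2 to compound 4 (0.18 log units; within the scatter)) and (a 1.5-fold lower number from compound 1 to compound 4 (0.17 log units; within the scatter)), so all exchanges at this aromatic carbon, para to a large group, now remain within the scatter, even with a larger group that carries a donor. Nothing at hand explains these numbers.

Still open, going by these compounds, is whether an amine or a carboxylic acid on this carbon, or a longer chain in place of the acetyl part of acetamido, would move the number beyond the scatter. On these data alone, all four compounds share the same core, so the effect of exchanges elsewhere on it also remains open.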